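Methoxy added to a sulfonamide series that shows no inhibition

The source may hold more compounds than are shown below. What is called first, only, known or untested is meant among the compounds shown, and "the series" means these compounds.

Compound 1, `C=Cc1ccc(S(=O)(=O)Nc2ccc3oc(-c4ccccc4)nc3c2)cc1`, in an assay on isolated protein for inhibition of malate dehydrogenase, mitochondrial (Sus scrofa), with stated times of 45 min and 30 min; on this read-out higher numbers stand for weaker inhibition and lower numbers for stronger inhibition: > 63000 nM, a limit of the assay.
Compound 2, `O=S(=O)(Nc1ccc2oc(-c3ccccc3)nc2c1)c1ccccc1F`, in this assay: > 63000 nM, a limit of the assay.
Compound 3, `O=S(=O)(Nc1ccc2oc(-c3ccccc3)nc2c1)c1cccc(Cl)c1`, in this assay: > 63000 nM, a limit of the assay.

All three measured compounds share one core and differ only in the ring on the sulfonyl sulfur. None of the three gives a number, only a limit, so each step between them is unreadable: a step that the two limits leave unreadable from compound 1 to compound 2, a step that the two limits leave unreadable from compound 1 to compound 3 and a step that the two limits leave unreadable from compound 2 to compound 3. For the measured compounds named here, the only evidence is the limit of > 63000 nM in this assay, at which 3 of the 3 values shown sit.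

Compound 4, `COc1ccc(Cl)cc1S(=O)(=O)Nc1ccc2oc(-c3ccccc3)nc2c1`, is compound 3 with one addition: methoxy in place of hydrogen on an aromatic carbon. Going by the values given here, no measured step shows what a methoxy group does here, since every comparison rests on limits. The three limits do point one way: three rings of different substitution all failed to reach the measurable range, so compound 4 is most likely to do the same. The expected step from compound 3 to compound 4 is therefore a step that the limit leaves unreadable from compound 3 to compound 4, meaning no readable change. For compound 4 the estimate in this assay is 90000 nM, with a range from 20000 nM to 400000 nM, and a limit rather than a number is the most probable outcome.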

Compound 4, half-maximal inhibitory concentration: > 63000 nM
Compound 4 gave a limit, no number (the forecaster's own chance of this, stated with the estimate: 80%); the middle value lies beyond the limit too.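

Compound 4 also gives only a limit in this assay, so the steps to it from compound 1, compound 2 and compound 3 cannot be read: the limit of > 63000 nM in this assay, at which 4 of the 4 values shown sit.

The compounds shown leave open whether any ring on the sulfonyl sulfur of this shared core can give a measurable inhibition, and so what a methoxy group does here.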